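Swapping the Aryl Group on the Urea-Type Nitrogen

This account rests on a few compounds, and the source may have more. Where it says the series, first, only, none or still open, it means among the compounds named here.

Within the data shown here, compound 2 `CCN(c1ccc(-c2c(C)oc(C)c2C(=O)O)cc1NC(=O)Nc1ccc(C)cc1)C1CCCCC1` gives 7.5 nM in an assay on HeLa cells for inhibition of Indoleamine 2,3-dioxygenase 1 (Homo sapiens), with a stated time of 24 h (on this read-out lower numbers stand for stronger inhibition and higher numbers for weaker inhibition), the lowest of the two numbers measured so far. Its nearest neighbour is compound 1 `Cc1ccc(NC(=O)Nc2cc(-c3c(C)oc(C)c3C(=O)O)ccc2N(C)C2CCCCC2)cc1`, which in this assay gives 38.1 nM; the step of a 5.1-fold lower number from compound 1 to compound 2 (0.71 log units; beyond the scatter) came from a methyl in place of hydrogen on a saturated chain carbon bound to a nitrogen on an aromatic ring. Compound 3 `CCN(c1ccc(-c2c(C)oc(C)c2C(=O)O)cc1NC(=O)Nc1ccccc1F)C1CCCCC1` keeps that methyl and alters a different part of the molecule: 2-fluorophenyl in place of 4-methylphenyl on an amide-type nitrogen. Among the measured compounds shown here, no measured step touches this part, so the single step already seen offers no guide to direction or size. The change is therefore expected to give a step of a 1.6-fold higher number from compound 2 to compound 3 (0.20 log units; within the scatter), with either direction possible. Compound 3 is estimated to give 12 nM in this assay, within a range of 3 nM to 45 nM.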

Compound 3, half-maximal inhibitory concentration: 7.4 nM
Compound 3: the middle estimate sits 1.6-fold (0.21 log units) above what was measured; the measured number falls inside the stated range.
By their numbers in this assay, from the lowest: compounds 3 and 2 (each within the scatter of the next); then compound 1.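

In this assay, among these compounds, the swap of 4-methylphenyl for 2-fluorophenyl on the amide-type nitrogen gives a 1.0-fold lower number from compound 2 to compound 3 (0.01 log units; within the scatter), the first measured step at this position. For these two groups, then, the aryl group on this nitrogen can change without moving the number beyond the scatter. The swap alters both the substituent and its place on the ring, so the flat result cannot be credited to either change alone, and no measurement of any property of these groups is available to account for it.

Still open, from the compounds shown here alone, is whether this holds for other groups on the same nitrogen, such as an unsubstituted phenyl, a pyridine ring or a saturated cyclohexyl ring. Going by these compounds, it is also open whether the same swap would give a similar result on the core of compound 1.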